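Trimming the ketone side chain of a glutamate receptor modulator

The source may report more compounds than this note shows. Statements on the series, on what has been measured and on what is new or still open speak of the compounds shown alone.

Three compounds share a core in which two aromatic rings are joined by a four-carbon chain between two ether oxygens. Compound 1 `Cc1c(OCCCCOc2ccc(C(=O)CC(C)(C)C)c(O)c2C)cccc1C(=O)O` carries a neopentylcarbonyl group and an acid on the far ring; in an assay on HEK293 cells for positive allosteric modulation of metabotropic glutamate receptor 2 (Rattus norvegicus), read by thallium flux, with a stated time of 2.5 min (a higher number here means a larger maximal response, a lower number a smaller maximal response), compound 1 gives 95.8%. Compound 2 `Cc1c(OCCCCOc2ccccc2C(=O)O)ccc(C(=O)CC(C)C)c1O` gives 92.4% in this assay, and compound 3 `Cc1c(OCCCCOc2ccc(C(=O)O)cc2)ccc(C(=O)CC2CCCC2)c1O` gives 82.6%. Compound 1 thus has the largest of the three numbers, yet its gap to compound 2 lies within the scatter and says nothing about order, while its gap to compound 3 lies beyond the scatter.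

Compound 4 `Cc1c(OCCCCOc2ccc(C(=O)C(C)C)c(O)c2C)cccc1C(=O)O` differs from compound 1 in one place: isopropyl in place of neopentyl on a carbonyl carbon. Within the data shown here, no measured pair shows this exact change, so the expected step from compound 1 to compound 4 is taken as small, and is estimated at a number 5.8 percentage points lower from compound 1 to compound 4 (within the scatter), a shift that stays within the scatter. Compound 4 is therefore expected to reach 90% in this assay, with a range from 78% to 100%.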

Compound 4, largest response reached (reported as percent of maximum), in percent of the reference or control that the assay uses: 66.9%
For compound 4 the middle estimate is 23.1 percentage points above the measured one; measured number below the stated range.
By their numbers in this assay, from the lowest: compound 4; then compounds 3, 2 and 1 (each within the scatter of the next, the first and the last beyond it).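

In this assay, putting isopropyl in place of neopentyl on a carbonyl carbon gives a number 28.9 percentage points lower from compound 1 to compound 4 (beyond the scatter). Among these compounds, this is the first comparison here that changes one place alone, and it shows that the maximal response depends on the group at this carbonyl: going from 5 heavy atoms to 3, with no ring, donor, acceptor or charge involved, is enough to give a step beyond the scatter. Nothing available explains why this step is so large.

A straight butyl chain or a tert-butyl group on the same carbonyl carbon could show whether the response follows chain length or branching. One pair also cannot tell whether a similar change would give a step of similar size on the frameworks of compound 2 or compound 3.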